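Naphthalen-1-yl to phenyl on compound 1

A few compounds are considered here, and "the series" means these few. Any claim that something is new, unique, unknown or untested is made for them only; others in the source may bear on it.

Among the measured compounds shown here, in a functional assay on COLO 205 cells (Homo sapiens) for inhibition, read by sulforhodamine B assay, with a stated time of 48 h, tested at 50 uM (a lower number here means less inhibition of growth, a higher number more inhibition of growth at the concentration tested), compound 1 `COc1cc(/C=C/C(=O)/C=C/c2cccc3ccccc23)ccc1OCc1cn(CCOc2cc(=O)oc3ccccc23)nn1` gives 85%, the higher of the two numbers so far. Compound 2 `COc1cc(/C=C/C(=O)/C=C/c2cccs2)ccc1OCc1cn(CCCCCOc2cc(=O)oc3ccccc23)nn1` gives 30%, lower by more than the usual scatter. These two compounds differ in more than one place, so their gap cannot be assigned to any single change.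

The next compound is compound 3 `COc1cc(/C=C/C(=O)/C=C/c2ccccc2)ccc1OCc1cn(CCOc2cc(=O)oc3ccccc23)nn1`, which differs from compound 1 as follows: phenyl in place of naphthalen-1-yl on a double-bonded chain carbon bound to a double-bonded chain carbon. For the measured compounds named here, no measured pair sizes this change. With compound 1 at 85%, more room lies downward than upward, so a moderate fall in this assay is expected, beyond the scatter. The expected change is a number 20 percentage points lower from compound 1 to compound 3 (beyond the scatter). For compound 3 the estimate is 65%, with an expected range of 40% to 85%.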

Compound 3, percent growth inhibition at one concentration: 54%
The estimate for compound 3 lay 11 percentage points above the measured number; the range from low to high includes it.
By their numbers in this assay, from the lowest: compound 2; then compound 3; then compound 1.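

In this assay, among the compounds shown here, the swap of naphthalen-1-yl for phenyl gives a number 31 percentage points lower from compound 1 to compound 3 (beyond the scatter) and is the first change that can be read at a single place. The group on a double-bonded chain carbon bound to a double-bonded chain carbon therefore matters for this read-out, with the two-ring naphthalen-1-yl on the higher side of this pair and the rest of compound 1 unchanged. Nothing available bears on what lies behind this step.

One pair cannot tell whether the second aromatic ring itself or simply the size of the group carries the step. Open too, from the compounds shown here alone, is how a naphthalen-2-yl, a 4-methoxyphenyl or a pyridin-3-yl group would read at this place, and how a longer chain to the triazole nitrogen would read with naphthalen-1-yl kept.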